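The source may hold more compounds than are shown below. What is called first, only, known or untested is meant among the compounds shown, and "the series" means these compounds.

Going by the values given here, compound 1 `COc1cc(CN[C@H]2C3C4CC5C6C4CC3C6C52)cc(OC)c1OC` is one of two compounds measured in an assay on brain for displacement of a labelled ligand from Sigma non-opioid intracellular receptor 1 (Rattus norvegicus); on this read-out lower numbers stand for stronger inhibition and higher numbers for weaker inhibition. In this assay compound 1 gives 1010 nM. The second compound, compound 2 `COc1ccc(CN(C)[C@H]2C3C4CC5C3C(=O)C3C5C4C32)cc1OC`, carries a methyl on its amine nitrogen along with a different core and methoxy pattern; in this assay compound 2 gives 1040 nM. Compound 1 thus has the lower of the two numbers shown, but the gap to compound 2 falls within the usual scatter of such measurements, so the two values show the same level.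

The unmeasured compound 3 `COc1cc(CN(C)[C@H]2C3C4CC5C6C4CC3C6C52)cc(OC)c1OC` differs from compound 1 in one place: methyl in place of hydrogen on an amine nitrogen. Among the compounds with values here, no measured pair isolates this change. Since compound 2, which also bears a methyl on the amine nitrogen, gives 1040 nM, the expected step of a 1.1-fold lower number from compound 1 to compound 3 (0.05 log units; within the scatter) is none beyond the scatter. Compound 3 is therefore expected to give about 900 nM, within a range of 300 nM to 3000 nM.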

Compound 3, inhibition constant: 1220 nM
For compound 3 the middle estimate is 1.4-fold (0.13 log units) below the measured one, and the stated range covers the measured number.
By their numbers in this assay, from the lowest: compounds 1, 2 and 3 (each within the scatter of the next).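

In this assay, going by these compounds alone, this pair gives the first direct reading of methyl in place of hydrogen on an amine nitrogen, with a 1.2-fold higher number from compound 1 to compound 3 (0.08 log units; within the scatter). On the core of compound 1, then, the nitrogen carries the methyl without a shift that can be told from the scatter. The earlier compounds shown here offered no such reading: compound 2 differs from compound 1 in more than one place. No evidence on the cause of this result is available.

The compounds shown leave open whether an ethyl group, a longer chain or an acetyl group on this nitrogen would also keep the number at this level. Within the data shown here, they also offer no pair that tests the same change on the core of compound 2.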